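The source may report more compounds than this note shows. Statements on the series, on what has been measured and on what is new or still open speak of the compounds shown alone.

Series notes. Compound 1 `O=S(=O)(c1cccc(F)c1)c1cnc2c(F)cccc2c1-c1cccc(Cl)c1`, compound 2 `COc1ccc(S(=O)(=O)c2cnc3c(F)cccc3c2-c2cccc(Cl)c2)cc1` and compound 3 `N#Cc1cccc(S(=O)(=O)c2cnc3c(F)cccc3c2-c2cccc(Cl)c2)c1` share one core and differ only in the aryl on the sulfonyl sulfur. In an ADME assay on microsomes from liver (Homo sapiens) for metabolic stability, tested at 2.5 uM (a higher number here means faster removal of the compound, a lower number slower removal), compound 1 gives 0.56 mL/min, compound 2 gives 2.75 mL/min and compound 3 gives 1.11 mL/min. The measured steps are a 4.9-fold higher number from compound 1 to compound 2 (0.69 log units; beyond the scatter), a 2.0-fold higher number from compound 1 to compound 3 (0.30 log units; within the scatter) and a 2.5-fold lower number from compound 2 to compound 3 (0.39 log units; beyond the scatter). Compound 3 therefore stands second highest of the three numbers, with compound 1 nearest and compound 2 furthest from it.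

Compound 4 `N#Cc1cccc(S(=O)(=O)c2cnc3c(F)cccc3c2-c2ccc(Cl)cc2)c1` has not yet been measured. Against compound 3 the change is 4-chlorophenyl in place of 3-chlorophenyl on an aromatic carbon. None of the three measured steps touches this part of the molecule: each of them changes the aryl on the sulfonyl sulfur, while the 3-chlorophenyl stays the same in compound 1, compound 2 and compound 3. Among the compounds with values here, no measured step bears directly on the move from compound 3 to compound 4, and no direction can be read from the data. For compound 4 the expected step in this assay is a 1.0-fold lower number from compound 3 to compound 4 (0.00 log units; within the scatter), nothing beyond the scatter in either direction. Compound 4 is estimated to give 1.1 mL/min, with a range from 0.5 mL/min to 2.5 mL/min.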

Compound 4, intrinsic clearance in a liver preparation (reported as CLH), per the amount of preparation that the assay uses: 0.08 mL/min
Compound 4: the middle estimate sits 14-fold (1.14 log units) above what was measured; measured number below the stated range.
By their numbers in this assay, from the lowest: compound 4; then compounds 1 and 3 (each within the scatter of the next); then compound 2.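

Moving the chlorine around the phenyl ring, with the same atoms in compound 3 and compound 4, gives a 14-fold lower number from compound 3 to compound 4 (1.14 log units; beyond the scatter) in this assay. The earlier compounds shown here all carry the 3-chlorophenyl and vary only the aryl on the sulfonyl sulfur, so they gave no reading at this position; it now proves sensitive to the place of a single chlorine on the ring attached opposite the ring nitrogen, and this step is larger than the widest step among the sulfonyl aryl changes, a 4.9-fold higher number from compound 1 to compound 2 (0.69 log units; beyond the scatter) in the same read-out. No measurement at hand accounts for the size of this shift or explains why the 4-chlorophenyl differs so sharply from the 3-chlorophenyl.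

The compounds shown leave open whether the 4-chlorophenyl gives a similar step when the sulfonyl sulfur carries 3-fluorophenyl or 4-methoxyphenyl instead of 3-cyanophenyl. They also leave open whether the result depends on chlorine itself, or whether a fluoro, methoxy or trifluoromethyl group in the same ring position, or a plain phenyl, would read like compound 4 or like compound 3.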